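The compounds below may be only part of what the source reports. "The series", "measured", "known", "first", "only" and "open" are said of these compounds alone.

In a functional assay on Vero cells (Chlorocebus sabaeus) for cytotoxicity (a higher number here means a weaker inhibitor, a lower number a stronger inhibitor), compound 1 `Cc1cn([C@@H]2S[C@H](CO)[C@H]2CO)c(=O)[nH]c1=O` gives > 100000 nM, which is a limit of the assay and not a number. Compound 2 `O=c1ccn([C@@H]2S[C@H](CO)[C@H]2CO)c(=O)[nH]1` gives > 100000 nM, also a limit. Compound 3 `Nc1nc(O)c2ncn([C@@H]3S[C@H](CO)[C@H]3CO)c2n1` gives > 100000 nM, again a limit. Compound 1 therefore has no exact position, and the evidence is the limit of > 100000 nM in this assay, at which 3 of the 3 values shown sit. Compound 4 `Cc1cn([C@H]2S[C@@H](CO)[C@@H]2CO)c(=O)[nH]c1=O` is the mirror image of compound 1: the two compounds have the same atoms and bonds and differ only in configuration as drawn: 3 of 3 stereo elements differ (all stereocentres are inverted: mirror images); a stereocentre at a saturated ring carbon is drawn R in compound 1 and S in compound 4; a stereocentre at a saturated ring carbon is drawn S in compound 1 and R in compound 4; a stereocentre at a saturated ring carbon is drawn R in compound 1 and S in compound 4. Among the measured compounds shown here, the one measured step, a step that the two limits leave unreadable from compound 1 to compound 2, involves a different change and has no readable size, so no measured step speaks directly to this inversion. No step beyond the scatter is expected in this assay, and no direction can be favoured. The estimated step is a step that the limit leaves unreadable from compound 1 to compound 4. Compound 4 is expected to read 120000 nM, with an estimated range of 40000 nM to 300000 nM.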

Compound 4, half-maximal inhibitory concentration: > 100000 nM
Compound 4: a limit, no number; the forecaster's own chance of this, stated with the estimate: 85%; the middle value lies beyond the limit too.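

In this assay compound 4 gives > 100000 nM, a limit and not a number. Among the compounds shown here, compound 1 also stands at a limit, so no step between compound 1 and compound 4 can be read. The compounds shown leave open whether these mirror images differ at all in this assay.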